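A few compounds are considered here, and "the series" means these few. Any claim that something is new, unique, unknown or untested is made for them only; others in the source may bear on it.

Measured so far:
Compound 1 `Cc1n[nH]cc1-c1cccc2c1CCC2c1ncc[nH]1` gives 902 nM in a functional assay on CHO cells for agonist activity at Alpha-1B adrenergic receptor (Homo sapiens), read by FLIPR and calcium flux; on this read-out higher numbers stand for an effect only at larger amounts of compound and lower numbers for an effect already at smaller amounts.
Compound 2 `Cn1ccc(-c2cccc3c2CCC3c2ncc[nH]2)n1` gives only a limit in this assay, > 10000 nM.
Compound 3 `COc1cccc2c1CCC2c1ncc[nH]1` gives only a limit in this assay, > 10000 nM.

Compound 3 thus stands at the limit of > 10000 nM in this assay, at which 2 of the 3 values shown sit, and no number is known for it; it shares this position with one of the other two values shown.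

Compound 4 `Cn1nccc1-c1cccc2c1CCC2c1ncc[nH]1` differs from compound 3 in one place: 1-methyl-1H-pyrazol-5-yl in place of methoxy on an aromatic carbon. Within the data shown here, two measured steps bear on this change. The step of an at least 11-fold higher number from compound 1 to compound 3 (1.04 log units; beyond the scatter) shows that removing a pyrazole in favour of methoxy at this carbon moved the value to the limit, so the reverse exchange may bring a readable number back. Against this, an at least 11-fold higher number from compound 1 to compound 2 (1.04 log units; beyond the scatter) shows that a methylated pyrazole at the same carbon can also sit at the limit, and a step that the two limits leave unreadable from compound 2 to compound 3 gives no size. The step of an at least 3.3-fold lower number from compound 3 to compound 4 (0.52 log units; beyond the scatter) is therefore expected to lower the number, with wide uncertainty. Compound 4 is estimated at 3000 nM, within 700 nM to 12000 nM.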

Compound 4, half-maximal effective concentration: > 10000 nM
Compound 4 was reported as a limit (the forecaster's own chance of this, stated with the estimate: 40%); middle value at least 3.3-fold (0.52 log units) away from the limit.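

In this assay the exchange of methoxy for 1-methyl-1H-pyrazol-5-yl brings no readable number back, and compound 4 stays at a limit, so a five-membered aromatic ring with 2 hetero atoms on this carbon is not enough on its own: the limit of > 10000 nM in this assay, at which 3 of the 4 values shown sit.
Among these compounds, compound 1, with 3-methyl-1H-pyrazol-4-yl, remains the only compound with a number, and the exchange for 1-methyl-1H-pyrazol-5-yl gives an at least 11-fold higher number from compound 1 to compound 4 (1.04 log units; beyond the scatter).
The steps from compound 2 to compound 4 and from compound 3 to compound 4 cannot be read, as both ends are limits.

The pyrazole of compound 1 differs from those of compound 2 and compound 4 both in its attachment and in where its methyl sits, and these two differences remain unseparated. Open too, from the compounds shown here alone, is how 1-methyl-1H-pyrazol-4-yl, unsubstituted 1H-pyrazol-4-yl or an amine would read at this carbon.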